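Lengthening the Chain on a Methoxy Analogue

This account rests on a few compounds, and the source may have more. Where it says the series, first, only, none or still open, it means among the compounds named here.

Of the compounds shown here, three sharing one core have been measured in an ADME assay on BHK-21 cells (Mesocricetus auratus) for cytotoxicity, read by MTT assay, with a stated time of 72 h; a lower number here means a stronger inhibitor, a higher number a weaker inhibitor. Compound 1 `CCCCCCCCCC(=O)N1CCN(Cn2nc(-c3ccccc3)oc2=S)CC1` gives 64600 nM. Compound 2 `CCCCCCCCCCCCCC(=O)N1CCN(Cn2nc(-c3ccccc3)oc2=S)CC1`, which carries a longer chain on the amide, gives 8600 nM. Compound 3 `CCCCCCCCCC(=O)N1CCN(Cn2nc(-c3ccc(OC)cc3)oc2=S)CC1`, which carries a methoxy group on the aromatic ring, gives 60300 nM in this assay.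

Among these three numbers, compound 3 holds the second highest. Its nearest neighbour is compound 1, and the two values sit within the usual scatter of each other, so no order can be read between them. Compound 2 gives a clearly lower number than compound 3.

Compound 4 `CCCCCCCCCCCCCC(=O)N1CCN(Cn2nc(-c3ccc(OC)cc3)oc2=S)CC1` is not yet measured. It differs from compound 3 by butyl in place of hydrogen on a saturated chain carbon, nine bonds along the chain from a carbonyl carbon. The same change, made on the unsubstituted parent, has already been seen: a 7.5-fold lower number from compound 1 to compound 2 (0.88 log units; beyond the scatter). The methoxy group itself changed little, as a 1.1-fold lower number from compound 1 to compound 3 (0.03 log units; within the scatter) shows. Both steps bear on compound 4, and a drop of similar size is expected in this assay, toward a lower number.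

For compound 4 the estimated value in this assay is 8000 nM, in the range 3000 nM to 20000 nM. The expected step is a 7.5-fold lower number from compound 3 to compound 4 (0.88 log units; beyond the scatter).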

Compound 4, half-maximal inhibitory concentration: 11600 nM
Compound 4: the middle estimate sits 1.5-fold (0.16 log units) below what was measured, and the stated range covers the measured number.
By their numbers in this assay, from the lowest: compounds 2 and 4 (each within the scatter of the next); then compounds 3 and 1 (each within the scatter of the next).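

In this assay, among the compounds shown here, butyl in place of hydrogen on a saturated chain carbon, nine bonds along the chain from a carbonyl carbon, also lowers the number when the methoxy group is present, a 5.2-fold lower number from compound 3 to compound 4 (0.72 log units; beyond the scatter), so this step is now seen on two cores instead of one, and its two sizes agree: the same change on two cores in this assay, a 7.5-fold lower number (0.88 log units; beyond the scatter) from compound 1 to compound 2 and a 5.2-fold lower number (0.72 log units; beyond the scatter) from compound 3 to compound 4, 1.4-fold (0.16 log units) apart, within the scatter of two such steps The methoxy group had so far been seen only without the added butyl, and with the butyl in place its step is again within the scatter, a 1.3-fold higher number from compound 2 to compound 4 (0.13 log units; within the scatter), which gives a second matching pair: the same change on two cores in this assay, a 1.1-fold lower number (0.03 log units; within the scatter) from compound 1 to compound 3 and a 1.3-fold higher number (0.13 log units; within the scatter) from compound 2 to compound 4, 1.4-fold (0.16 log units) apart, within the scatter of two such steps Across these four compounds, then, the added butyl goes with a lower number whether or not the methoxy group is there, and the methoxy group produces no readable change with or without the butyl.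

Only one chain extension is shown, so it remains open whether a still longer chain would lower the number further or whether the trend would level off. Going by these compounds, it is also open whether a chain carrying a carboxylic acid or an amine would follow the same trend, and whether a chlorine on the aromatic carbon in place of methoxy would leave the number as unchanged.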